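This account rests on a few compounds, and the source may have more. Where it says the series, first, only, none or still open, it means among the compounds named here.

Measured compounds in the series:
- compound 1, `O=C(O)CC1CCCC1Cc1ccc(OCc2ccc3ccccc3n2)cc1`: 100 nM
- compound 2, `CC(CCc1nnn[nH]1)Cc1ccc(OCc2ccc3ccccc3n2)cc1`: 12 nM

Going by the values given here, in an assay on membranes from lung (Cavia porcellus) for binding affinity to cysteinyl leukotriene receptor (Homo sapiens) (on this read-out lower numbers stand for stronger inhibition and higher numbers for weaker inhibition), compound 2 gives the lower of the two numbers so far. Among the compounds with values here, the only step measured to date is an 8.3-fold lower number from compound 1 to compound 2 (0.92 log units; beyond the scatter), which exchanges the acidic side chain as a whole and says nothing about the chain carbon that carries the methyl in compound 2.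

Compound 3, `c1ccc(C(CCc2nnn[nH]2)Cc2ccc(OCc3ccc4ccccc4n3)cc2)cc1`, differs from compound 2 at that chain carbon only: phenyl in place of methyl on a saturated chain carbon bound to two saturated chain carbons. Within the data shown here, no measured pair isolates this place, so the step in this assay has no direct precedent; the one step known concerns a different part of the molecule and cannot be carried over. The expectation is therefore a step of a 1.2-fold lower number from compound 2 to compound 3 (0.08 log units; within the scatter), near the scatter, with no direction that the data support, the compound 2 value being the anchor. Compound 3 is expected to give about 10 nM in this assay, within a range of 3 nM to 35 nM, with the wide range reflecting the absence of a comparable step.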

Compound 3, inhibition constant: 8 nM
Estimate against measurement, compound 3: 1.3-fold (0.10 log units) above; the range from low to high includes it.
By their numbers in this assay, from the lowest: compounds 3 and 2 (each within the scatter of the next); then compound 1.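

In this assay, the saturated chain carbon bound to two saturated chain carbons accepts phenyl in place of methyl with a 1.5-fold lower number from compound 2 to compound 3 (0.18 log units; within the scatter), so compound 2 and compound 3 cannot be told apart on this read-out. The earlier step exchanged the side chain as a whole, whereas this pair isolates a single place and shows that one six-membered aromatic ring of carbon only can stand there instead of methyl without a difference beyond the scatter. No available evidence bears on why methyl and phenyl read alike here.

The compounds shown do not settle whether this place is equally undemanding for other groups, such as a hydrogen, an ethyl, a benzyl, a phenyl carrying a chlorine or a methoxy group, or an amine. They also leave open whether phenyl at this carbon would read the same with a carboxylic acid in place of the tetrazole at the chain end, and whether a longer chain between this carbon and the tetrazole would keep the numbers of compound 2 and compound 3.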